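This account rests on a few compounds, and the source may have more. Where it says the series, first, only, none or still open, it means among the compounds named here.

Measured compounds in a functional assay on the whole organism with Rattus norvegicus as the target, at a dose of 3 mg/kg by the oral route; on this read-out higher numbers stand for a stronger effect at the one dose given and lower numbers for a weaker effect:
- compound 1 `COc1cccc(-c2cc(Cl)cc(C(=O)Nc3nn[nH]n3)n2)c1` gives 95%
- compound 2 `CCCCc1ccc(-c2cc(Cl)cc(C(=O)Nc3nn[nH]n3)n2)cc1` gives 83%
- compound 3 `COc1cc(C(=O)Nc2nn[nH]n2)nc(-c2ccccc2OC)c1` gives 68%

Compound 1 stands highest of the three in this assay. Compound 2 sits below it by a margin beyond the scatter, and compound 3 further below still, also beyond the scatter. No pair among these three differs in a single place, so no measured step for any one change is available, and the three numbers can only be read as separate points.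

The next compound, compound 4 `COc1cccc(-c2cc(C)cc(C(=O)Nc3nn[nH]n3)n2)c1`, is to be measured in this assay. It differs from compound 1 as follows: methyl in place of chloro on an aromatic carbon

Within the data shown here, no measured step for this change exists, so the size of the step is not known from the data. Given that compound 1 already sits near the top of the read-out in this assay with 95%, the step is expected to be small and downward, as a number 10 percentage points lower from compound 1 to compound 4 (within the scatter), and may well stay within the scatter. Compound 4 is accordingly expected to give about 85% in this assay, with a range from 60% to 98%.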

Compound 4, a percentage reported as inhibition, in the whole organism at one dose (the size of the read-out at that dose, not a potency): 65%
For compound 4 the middle estimate is 20 percentage points above the measured one; measured number inside the range.
By their numbers in this assay, from the lowest: compounds 4 and 3 (each within the scatter of the next); then compound 2; then compound 1.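

In this assay, the series now has its first step in one place: methyl in place of chloro on the aromatic carbon opposite the ring nitrogen gives a number 30 percentage points lower from compound 1 to compound 4 (beyond the scatter) on the core of compound 1. The read-out at this position therefore depends on which group it carries, even though the exchanged groups match in heavy-atom count and neither adds a hydrogen-bond donor, hydrogen-bond acceptor or net charge. No measurement shown here explains the drop.

On these data alone, whether chloro is preferred over groups beyond methyl remains open, as a fluoro, bromo, trifluoromethyl or nitrile group at this position could read either way. It is also open whether the same step would appear with the other aryl groups seen in compound 2 and compound 3, since this exchange is shown only on the core of compound 1.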